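The source may report more compounds than this note shows. Statements on the series, on what has been measured and on what is new or still open speak of the compounds shown alone.

Measured compounds in a functional assay on Jurkat cells for inhibition of nuclear factor NF-kappa-B complex (Homo sapiens); a higher number here means a weaker inhibitor, a lower number a stronger inhibitor:
- compound 1 `CCOC(=O)c1cnc(-c2ccc(Cl)cc2)nc1NN1C(=O)C=C(C)C1=O` gives 300 nM
- compound 2 `CCOC(=O)c1cnc(-c2ccc(C(F)(F)F)cc2)nc1NN1C(=O)C=C(C)C1=O` gives 400 nM
- compound 3 `CCOC(=O)c1cnc(-c2cccc(Br)c2)nc1NN1C(=O)C=C(C)C1=O` gives 700 nM

Among these three numbers, compound 3 stands apart only from compound 1, through a 2.3-fold higher number from compound 1 to compound 3 (0.37 log units; beyond the scatter); against compound 2 the gap is a 1.8-fold higher number from compound 2 to compound 3 (0.24 log units; within the scatter). Compound 4 `CCOC(=O)c1cnc(C2CC2)nc1NN1C(=O)C=C(C)C1=O` differs from compound 3 by cyclopropyl in place of 3-bromophenyl on an aromatic carbon. For the measured compounds named here, no measured step matches this change: a 1.3-fold higher number from compound 1 to compound 2 (0.12 log units; within the scatter) and the two steps ending at compound 3 all exchange one aromatic group for another at the same carbon, and all stay small or modest. The aromatic ring itself is never removed in the measured set. For compound 4 a higher number is expected, estimated as a 4.3-fold higher number from compound 3 to compound 4 (0.63 log units; beyond the scatter). The estimate for compound 4 in this assay is 3000 nM, expected to lie between 900 nM and 15000 nM.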

Compound 4, half-maximal inhibitory concentration: 1000 nM
Compound 4: middle estimate off by 3.0-fold (0.48 log units), on the high side; measured number inside the range.
By their numbers in this assay, from the lowest: compounds 1, 2, 3 and 4 (each within the scatter of the next, the first and the last beyond it).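

In this assay, removing the aromatic ring at this carbon, between two ring nitrogen atoms, costs little: cyclopropyl in compound 4 stays within the scatter of 3-bromophenyl (a 1.4-fold higher number from compound 3 to compound 4 (0.15 log units; within the scatter)). The gaps from the two para-substituted phenyl compounds remain modest (a 2.5-fold higher number from compound 2 to compound 4 (0.40 log units; beyond the scatter); a 3.3-fold higher number from compound 1 to compound 4 (0.52 log units; beyond the scatter)), so among these compounds an aromatic ring at this carbon is not needed for activity in this range. No evidence is given that explains this result.

As far as these compounds go, whether an amine or a longer alkyl chain at this carbon would fit the same range remains open. So does the effect of a carboxylic acid in place of the ethoxycarbonyl group.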